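The source may hold more compounds than are shown below. What is called first, only, known or untested is meant among the compounds shown, and "the series" means these compounds.

Compound 1, `CCOC(=O)c1sc(-c2cccc(NC(=O)c3ccc(F)cc3)c2)nc1Nc1ccc(N2CCN(C)CC2)cc1`: in a functional assay on Ramos cells (Homo sapiens) for antiproliferative activity, read by CCK-8 assay, with a stated time of 72 h, tested at 40 uM (a lower number here means less inhibition, a higher number more inhibition at the concentration tested (going by the name of the read-out)), compound 1 gives 3.53%
Compound 2, `CN1CCN(c2ccc(Nc3nc(-c4cccc(NC(=O)c5ccccc5F)c4)sc3C(=O)O)cc2)CC1`: compound 2 gives 93.4%
Compound 3, `CN1CCN(c2ccc(Nc3nc(-c4cccc(NC(=O)c5ccc(F)cc5)c4)sc3C(N)=O)cc2)CC1`: compound 3 gives 95.9%

Among the compounds with values here, compound 3 and compound 2 sit together at the upper end of these three numbers, within the scatter of each other, while compound 1 lies far below them; the only measured step, a number 92.4 percentage points higher from compound 1 to compound 3 (beyond the scatter), is large. Compound 4, `CN1CCN(c2ccc(Nc3nc(-c4cccc(NC(=O)c5ccc(Cl)cc5)c4)sc3C(N)=O)cc2)CC1`, differs from compound 3 by chloro in place of fluoro on an aromatic carbon. Within the data shown here, no measured step concerns this change; the one step known, a number 92.4 percentage points higher from compound 1 to compound 3 (beyond the scatter), sits on the carbonyl carbon and says nothing about the aromatic ring. Compound 4 is therefore expected to keep the level of compound 3, with a step of a number 2.9 percentage points lower from compound 3 to compound 4 (within the scatter) that stays within the scatter. Compound 4 is estimated at 93%, in a range from 80% to 99%.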

Compound 4, a percentage reported as inhibition, at one concentration (the size of the read-out at that concentration, not a potency): 99%
The estimate for compound 4 lay 6 percentage points below the measured number; the range from low to high includes it.
By their numbers in this assay, from the lowest: compound 1; then compounds 2, 3 and 4 (each within the scatter of the next).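

Chloro in place of fluoro on this aromatic carbon, para to a large group, gives a number 3.1 percentage points higher from compound 3 to compound 4 (within the scatter) in this assay, the first measured change at this place. The high level therefore holds with either 4-fluorophenyl or 4-chlorophenyl, although a reading at one concentration is not a potency and cannot show whether the two differ at lower concentrations. Nothing shown offers an explanation for this result. Open, going by these compounds, is what a methoxy group or an amine at this place would give, and whether a chloro group would keep this level beside a carboxylic acid on the carbonyl carbon.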